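This account rests on a few compounds, and the source may have more. Where it says the series, first, only, none or still open, it means among the compounds named here.

Compound 1, `CCN(C/C=C/C#CC(C)(C)C)Cc1cccc(OC[Si](C)(C)c2ccc(Br)cc2)c1`, gives 210 nM in a functional assay on liver (Sus scrofa) for inhibition of squalene monooxygenase (Homo sapiens), using microsomes; a lower number here means a stronger inhibitor, a higher number a weaker inhibitor.
Compound 2, `CCN(C/C=C/C#CC(C)(C)C)Cc1cccc(OC[Si](C)(C)c2ccc(OC)cc2)c1`, gives 870 nM.
Compound 3, `CCN(C/C=C/C#CC(C)(C)C)Cc1cccc(OC[Si](C)(C)c2cccc(C)c2)c1`, gives 3000 nM.

Compound 3 has the highest number of the three, standing above compound 2 by a 3.4-fold higher number from compound 2 to compound 3 (0.54 log units; beyond the scatter) and above compound 1 by a 14-fold higher number from compound 1 to compound 3 (1.15 log units; beyond the scatter). Compound 4, `CCN(C/C=C/C#CC(C)(C)C)Cc1cccc(OC[Si](C)(C)c2ccccc2C)c1`, differs from compound 3 by 2-methylphenyl in place of 3-methylphenyl on a silicon. The two steps that exchange the aryl group on silicon, a 14-fold higher number from compound 1 to compound 3 (1.15 log units; beyond the scatter) and a 3.4-fold higher number from compound 2 to compound 3 (0.54 log units; beyond the scatter), show that this group can shift the number markedly, but neither moves a methyl within the ring, so the direction for compound 4 is open. A modest step in this assay in either direction, or none beyond the scatter, seems plausible. Compound 4 is therefore estimated at 3000 nM, within 1000 nM to 9000 nM, and the expected step is no change at the digits printed from compound 3 to compound 4 (within the scatter).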

Compound 4, half-maximal inhibitory concentration: 30 nM
Beside the measured number, compound 4's estimate is 100-fold (2.00 log units) above it; the measured number lies below the stated range.
By their numbers in this assay, from the lowest: compound 4; then compound 1; then compound 2; then compound 3.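

Moving the methyl within the ring, with the same atoms in a new arrangement, gives a 100-fold lower number from compound 3 to compound 4 (2.00 log units; beyond the scatter) in this assay, so the methyl's place on the aryl group on silicon matters greatly. The 2-methylphenyl group also gives lower numbers than the other two aryl groups, with a 29-fold lower number from compound 2 to compound 4 (1.46 log units; beyond the scatter) and a 7.0-fold lower number from compound 1 to compound 4 (0.85 log units; beyond the scatter). No data shown here explain this effect.

Still open, as far as these compounds go, is whether 2-chlorophenyl or 2-methoxyphenyl on the silicon would give a similarly low number. Also open, from the compounds shown here alone, is whether a 4-bromo-2-methylphenyl group would lower it further.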